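The source may report more compounds than this note shows. Statements on the series, on what has been measured and on what is new or still open speak of the compounds shown alone.

Three compounds have so far been measured in a functional assay on LNCaP cells (Homo sapiens) for antiproliferative activity, read by CCK-8 assay, with a stated time of 6 days; on this read-out lower numbers stand for stronger inhibition and higher numbers for weaker inhibition:
compound 1 `CC(O)c1ccc(C(=O)N[C@@H](C)Cn2ccc(-c3ccc(C#N)c(Cl)c3)n2)cc1` gives 3690 nM;
compound 2 `COc1ccc(C(=O)N[C@@H](C)Cn2ccc(-c3ccc(C#N)c(Cl)c3)n2)cc1` gives 3410 nM;
compound 3 `COC(=O)/C=C/C(=O)N[C@@H](C)Cn1ccc(-c2ccc(C#N)c(Cl)c2)n1` gives 2460 nM.

Compound 3 has the lowest of the three numbers, but its distance to compound 2 and to compound 1 stays within the scatter of repeated measurements, so the three cannot be told apart on these data.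

Compound 4 `C[C@@H](Cn1ccc(-c2ccc(C#N)c(Cl)c2)n1)Nc1ccccn1` differs from compound 3 by a single change: pyridin-2-yl in place of (2-(methoxycarbonyl)ethenyl)carbonyl on an amine nitrogen. The amide carbonyl that all three measured compounds share is thus gone, and an aromatic ring sits directly on the nitrogen.

Among the compounds with values here, two measured steps touch the same part of the molecule, though less deeply. The step of a 1.5-fold lower number from compound 1 to compound 3 (0.18 log units; within the scatter) and the step of a 1.4-fold lower number from compound 2 to compound 3 (0.14 log units; within the scatter) each swapped the group on the carbonyl carbon and left the amide itself in place, and neither moved the number beyond the scatter. Within the data shown here, no measured step removes the carbonyl, so the present change reaches further than anything observed. The expectation is therefore a step of a 1.2-fold higher number from compound 3 to compound 4 (0.09 log units; within the scatter) of no clear direction, with a wide range to cover the untested change.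

Compound 4 is estimated at 3000 nM in this assay, expected to fall between 700 nM and 13000 nM.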

Compound 4, half-maximal inhibitory concentration: 1110 nM
For compound 4 the middle estimate is 2.7-fold (0.43 log units) above the measured one; measured number inside the range.
By their numbers in this assay, from the lowest: compound 4; then compounds 3, 2 and 1 (each within the scatter of the next).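

In this assay the carbonyl on this amine nitrogen proves dispensable, since replacing the (2-(methoxycarbonyl)ethenyl)carbonyl group with pyridin-2-yl gives a 2.2-fold lower number from compound 3 to compound 4 (0.35 log units; beyond the scatter) and activity is not lost. Within the data shown here, this modest step is the first to pass beyond the scatter; the earlier swaps changed only the group on the carbonyl carbon, left the amide in place and could not be told from repeat-measurement noise, so this position can move the number once the change reaches the nitrogen itself. Nothing available explains why the number falls here.

The step bundles two events, the loss of the carbonyl and the arrival of an aromatic ring carrying a ring nitrogen, and the compounds shown cannot separate them. A plain phenyl group on the same amine nitrogen would ask whether the ring nitrogen matters, while a small saturated group such as methyl or cyclopropyl would ask whether any aromatic ring is needed there at all.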